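Second chloro on the shared core: expectation for compound 4

A few compounds are considered here, and "the series" means these few. Any claim that something is new, unique, unknown or untested is made for them only; others in the source may bear on it.

Measured values in a functional assay on SN12C cells (Homo sapiens) for cytotoxicity, read by sulforhodamine B assay, with a stated time of 48 h; a lower number here means a stronger inhibitor of growth, a higher number a weaker inhibitor of growth:

compound 1 `ClCc1ccc(Cn2cnc3c(Cl)ncnc32)cc1`: 1020 nM
compound 2 `ClCc1cccc(Cn2cnc3ncnc(Cl)c32)c1`: 7070 nM
compound 3 `ClCc1cccc(Cn2cnc3c(Cl)ncnc32)c1`: 2340 nM

Compound 1 carries the lowest number of the three. Compound 3 is nearest, beyond the scatter, and compound 2 is furthest, also beyond the scatter. No two of these compounds differ in only one place, so no single-change step is available to lean on.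

Compound 4 `ClCc1ccc(Cn2cnc3c(Cl)nc(Cl)nc32)cc1` differs from compound 1 by chloro in place of hydrogen on an aromatic carbon. Among the measured compounds shown here, no measured pair shows this change, so what follows is an expectation alone. The step from compound 1 to compound 4 is expected to be small, a 1.3-fold lower number from compound 1 to compound 4 (0.11 log units; within the scatter), not clearly beyond the scatter in either direction. For compound 4 in this assay the estimate is 800 nM, within 300 nM to 2500 nM.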

Compound 4, concentration for 50% growth inhibition: 7240 nM
Compound 4: the middle estimate sits 9.1-fold (0.96 log units) below what was measured; measured number above the stated range.
By their numbers in this assay, from the lowest: compound 1; then compound 3; then compounds 2 and 4 (each within the scatter of the next).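

In this assay, among the compounds shown here, the first single-change step shows that this position is sensitive: on the aromatic carbon between two ring nitrogen atoms, chloro in place of hydrogen gives a 7.1-fold higher number from compound 1 to compound 4 (0.85 log units; beyond the scatter). On this one pair, hydrogen is the better of the two groups seen at this position. Nothing measured here accounts for the step.

Going by these compounds, whether an amine, a methoxy group or a fluoro group at this position would stay close to compound 1 remains open. On these data alone, whether the same change gives a step of similar size starting from compound 3 also remains open.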